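This account rests on a few compounds, and the source may have more. Where it says the series, first, only, none or still open, it means among the compounds named here.

Compound 1 `Cc1nnc(SCC(=O)N/N=c2/scc(-c3ccc(F)cc3)n2-c2ccccc2)s1` gives 37.4%. Compound 2 `Cn1nnnc1SCC(=O)N/N=c1/scc(-c2ccc([N+](=O)[O-])cc2)n1-c1ccccc1` gives 69.2%. Compound 3 `O=C(CSc1nnnn1-c1ccccc1)N/N=c1/scc(-c2ccc(Br)cc2)n1-c1ccccc1` gives 32%.

In a functional assay on C6 cells (Rattus norvegicus) for cytotoxicity, read by MTT assay, with a stated time of 24 h, tested at 50 ug/mL (a higher number here means a weaker effect of the compound at the concentration tested, a lower number a stronger effect), compound 2 stands highest of the three numbers; its gaps to compound 1 and to compound 3 both lie beyond the scatter, so compound 2 is the weakest of the three at this concentration. Compound 4 `Cc1ccc(-c2cs/c(=N/NC(=O)CSc3nnnn3C)n2-c2ccccc2)cc1` has not yet been tested in this assay. It differs from compound 2 in one place: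

methyl in place of nitro on an aromatic carbon

For the measured compounds named here, no measured pair shows this change, so its size is not known from the data. Since compound 1 and compound 3 both sit well below compound 2, a moderate step downward is expected, a number 17.2 percentage points lower from compound 2 to compound 4 (beyond the scatter). Compound 4 is thus estimated to give 52%, with a range from 32% to 72%.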

Compound 4, a percentage reported as activity, at one concentration (the size of the read-out at that concentration, not a potency): 44.3%
Estimate against measurement, compound 4: 7.7 percentage points above; low and high end bracket the measured number.
By their numbers in this assay, from the lowest: compounds 3, 1 and 4 (each within the scatter of the next, the first and the last beyond it); then compound 2.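

In this assay the change from 4-nitrophenyl to 4-methylphenyl gives the first step read in one place, a number 24.9 percentage points lower from compound 2 to compound 4 (beyond the scatter), so the group on this aromatic carbon clearly affects the read-out at the concentration tested. With the rest of the structure unchanged, the methyl compound shows the stronger effect. Nothing at hand explains this step. From the compounds shown here alone, whether an amine or a carboxylic acid at this position would shift the read-out further, and in which direction, remains open, as does whether this change would act alike with the other groups on the shared core.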